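The source may report more compounds than this note shows. Statements on the series, on what has been measured and on what is new or still open speak of the compounds shown alone.

Compound 1 `CCCCOc1ccc(NS(=O)(=O)c2ccc(N3CCNC3=O)cc2)cc1` gives 630 nM in a functional assay on HT-29 cells (Homo sapiens) for antiproliferative activity, read by sulforhodamine B assay, with a stated time of 48 h; on this read-out higher numbers stand for weaker inhibition and lower numbers for stronger inhibition.
Compound 2 `O=C1NCCN1c1ccc(S(=O)(=O)Nc2ccc(C3CCCCC3)cc2)cc1` gives only a limit, > 1000 nM, in this assay (the limit of > 1000 nM in this assay, at which 1 of the 3 values shown sits).
Compound 3 `O=C1NCCN1c1ccc(S(=O)(=O)Nc2ccc(I)cc2)cc1` gives 650 nM in this assay.

Compound 3 holds the higher of the two numbers, with compound 1 within the scatter of it a 1.0-fold higher number from compound 1 to compound 3 (0.01 log units; within the scatter). The step to compound 4 `Cc1ccc(C)c(NS(=O)(=O)c2ccc(N3CCNC3=O)cc2)c1` is 2,5-dimethylphenyl in place of 4-iodophenyl on a sulfonamide nitrogen. The measured steps at the same place are a 1.0-fold higher number from compound 1 to compound 3 (0.01 log units; within the scatter) and an at least 1.5-fold lower number from compound 2 to compound 3 (0.18 log units; that floor lies within the scatter), plus an at least 1.5-fold higher number from compound 1 to compound 2 (0.20 log units; that floor lies within the scatter); none reaches beyond the scatter, and none exchanges a single group on that aromatic carbon for two methyl groups, so no direction is supported. A step of no more than the scatter is expected, a 1.1-fold higher number from compound 3 to compound 4 (0.03 log units; within the scatter). For compound 4 the estimate in this assay is 700 nM, between 300 nM and 1600 nM.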

Compound 4, half-maximal inhibitory concentration: 46 nM
Beside the measured number, compound 4's estimate is 15-fold (1.18 log units) above it; measured number outside the range, below it.
By their numbers in this assay, from the lowest: compound 4; then compounds 1 and 3 (each within the scatter of the next). At a limit, above all of these: compound 2.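

Among the compounds shown here, on the sulfonamide nitrogen, 2,5-dimethylphenyl in place of 4-iodophenyl gives a 14-fold lower number from compound 3 to compound 4 (1.15 log units; beyond the scatter), the first step beyond the scatter in this assay. None of the earlier exchanges of a single group on the aromatic carbon reached beyond the scatter, so the aryl group at this position can move the number strongly. Nothing measured in the data shown accounts for the step.

Open, from the compounds shown here alone, is whether either methyl group alone carries the step. Also open, going by these compounds, is whether methoxy or chloro groups in place of the two methyl groups would give a similar number.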